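Swapping an aryl ether for a biaryl on the shared core

A few compounds are considered here, and "the series" means these few. Any claim that something is new, unique, unknown or untested is made for them only; others in the source may bear on it.

Compound 1 `COc1cccc(CNCCCNc2ccnc3cc(Oc4ccc(Cl)cc4)ccc23)c1O` was tested in an ADME assay on HepG2 cells (Homo sapiens) for cytotoxicity, read by luminescence, CellTiter-Glo and ATP content, with a stated time of 72 h (a lower number here means that less compound is needed, a higher number that more compound is needed for the effect), where compound 1 gives 5700 nM. Among the three measured compounds it holds the second highest number: compound 2 `c1ccc(CCc2ccc3c(NCCCNCc4ccco4)ccnc3c2)cc1` gives 16000 nM, while compound 3 `c1coc(CNCCCNc2ccnc3cc(CC4CCCCC4)ccc23)c1` gives 1700 nM, so compound 1 sits between them, beyond the scatter from each.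

Compound 4 `COc1cccc(CNCCCNc2ccnc3cc(-c4ccc(F)cc4)ccc23)c1O` differs from compound 1 at one place on the shared core: 4-fluorophenyl in place of 4-chlorophenoxy on an aromatic carbon. Among the compounds with values here, the only measured step, a 9.4-fold lower number from compound 2 to compound 3 (0.97 log units; beyond the scatter), changes the same aromatic carbon, but it exchanges cyclohexyl for benzyl on a saturated chain carbon, not 4-fluorophenyl for 4-chlorophenoxy, so it bears on the new step only loosely; it shows that this position can move the number, without showing the direction for this particular exchange.

The account therefore expects a step of a 1.1-fold lower number from compound 1 to compound 4 (0.06 log units; within the scatter) for compound 4, essentially within the scatter. Compound 4 is estimated at 5000 nM, with a range from 1500 nM to 16000 nM.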

Compound 4, half-maximal effective concentration: 6840 nM
For compound 4 the middle estimate is 1.4-fold (0.14 log units) below the measured one; the measured number falls inside the stated range.
By their numbers in this assay, from the lowest: compound 3; then compounds 1 and 4 (each within the scatter of the next); then compound 2.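

At this aromatic carbon on the shared core, the exchange of 4-chlorophenoxy for 4-fluorophenyl in this assay gives a 1.2-fold higher number from compound 1 to compound 4 (0.08 log units; within the scatter), so this position does not respond to every exchange with a step beyond the scatter, as it did in a 9.4-fold lower number from compound 2 to compound 3 (0.97 log units; beyond the scatter). The exchange removes the ether oxygen and replaces chlorine with fluorine in a single step, so compound 1 and compound 4 lying within the scatter of each other cannot be assigned to either part alone. Nothing measured here accounts for this result.

The compounds shown leave open how 4-chlorophenyl or 4-fluorophenoxy would read on the same carbon, which would separate the two parts of the exchange. They also leave open how an amine or a carboxylic acid would read at this position.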